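The source may hold more compounds than are shown below. What is called first, only, known or untested is meant among the compounds shown, and "the series" means these compounds.

Compound 1 `O=C(NCc1cn(Cc2ccc(Cl)cc2)nn1)c1cn(-c2ccccc2)nc1-c1ccccc1`: > 100000 nM
Compound 2 `O=C(NCc1cn(Cc2ccc(C(F)(F)F)cc2)nn1)c1cn(-c2ccccc2)nc1-c1ccccc1`: 840 nM
Compound 3 `O=C(NCc1cn(Cc2ccc(Cl)cc2)nn1)c1cn(-c2ccccc2)nc1-c1ccc(Cl)cc1`: 28800 nM
Compound 4 `O=C(NCc1cn(Cc2ccc(C(F)(F)F)cc2)nn1)c1cn(-c2ccccc2)nc1-c1ccc(Cl)cc1`: not yet measured

The series is followed in a functional assay on MCF7 cells (Homo sapiens) for antiproliferative activity, read by sulforhodamine B assay, with a stated time of 48 h; a higher number here means a weaker inhibitor of growth, a lower number a stronger inhibitor of growth. For compound 1 the value > 100000 nM is a limit of the assay and not a number. Compound 2 gives 840 nM in this assay, and compound 3 gives 28800 nM.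

The change from compound 1 to compound 2 is trifluoromethyl in place of chloro on an aromatic carbon and makes a step of an at least 110-fold lower number from compound 1 to compound 2 (2.07 log units; beyond the scatter). The size of that step rests on (the limit of > 100000 nM in this assay, at which 1 of the 3 values shown sits), so only its lower bound is known. The change from compound 1 to compound 3 is chloro in place of hydrogen on an aromatic carbon, with a step of an at least 3.4-fold lower number from compound 1 to compound 3 (0.54 log units; beyond the scatter). Compounds 2 and 3 differ in two places; no single step connects them, and their two values simply stand as shown.

Compound 4 carries the change already seen from compound 1 to compound 2, now on the core of compound 3: trifluoromethyl in place of chloro on an aromatic carbon. The place of the change is the same in both pairs, word for word, so this is the same change on a core that differs by the chloro described above. The measured step from compound 1 to compound 2 is the basis for expecting a comparable drop here, as is compound 3 at 28800 nM as the starting point. In this assay the step from compound 3 to compound 4 is expected to be a 96-fold lower number from compound 3 to compound 4 (1.98 log units; beyond the scatter), set beside an at least 110-fold lower number from compound 1 to compound 2 (2.07 log units; beyond the scatter). In this assay compound 4 is estimated at 300 nM, expected to fall between 80 nM and 1500 nM.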

Compound 4, concentration for 50% growth inhibition: 4900 nM
Compound 4: middle estimate off by 16-fold (1.21 log units), on the low side, and the stated range ends below it.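

In this assay trifluoromethyl in place of chloro still lowers the number on the core of compound 3, with a 5.9-fold lower number from compound 3 to compound 4 (0.77 log units; beyond the scatter), but the size of the step does not carry over from one core to the other: the same change on two cores in this assay, an at least 110-fold lower number (2.07 log units; beyond the scatter) from compound 1 to compound 2 and a 5.9-fold lower number (0.77 log units; beyond the scatter) from compound 3 to compound 4, at least 20-fold (1.30 log units) apart, beyond the scatter of two such steps
Chloro in place of hydrogen does not even keep its direction, since it gives an at least 3.4-fold lower number from compound 1 to compound 3 (0.54 log units; beyond the scatter) on one core but a 5.8-fold higher number from compound 2 to compound 4 (0.77 log units; beyond the scatter) on the other: the same change on two cores in this assay, an at least 3.4-fold lower number (0.54 log units; beyond the scatter) from compound 1 to compound 3 and a 5.8-fold higher number (0.77 log units; beyond the scatter) from compound 2 to compound 4, at least 20-fold (1.30 log units) apart, beyond the scatter of two such steps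
Compound 1 stands at > 100000 nM, a limit of the assay and not a number, so both gaps are known only as lower bounds, and the four compounds show that the two changes do not add up in this small set without showing why: the limit of > 100000 nM in this assay, at which 1 of the 4 values shown sits.

Open, going by these compounds, is whether this dependence on the core holds for other groups in the same place on the benzyl side, such as a methoxy, a nitrile or a fluoro, or only for the pair chloro and trifluoromethyl. Also open, on these data alone, is whether a bromo or a methoxy in place of the chloro of the 4-chlorophenyl group would raise the number on the core of compound 2 as chloro does in compound 4.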